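Replacing the Bicyclic Amine Arm of Compound 1

This account rests on a few compounds, and the source may have more. Where it says the series, first, only, none or still open, it means among the compounds named here.

Measured compounds:
compound 1 `O=C1CCC(=O)N1Cc1cc2nccc(-c3cc(Cl)cc4c3O[C@@H](c3onc5c3CNCC5)C4)c2s1` 0.38 nM
compound 2 `O=C(C1Cc2cc(Cl)cc(-c3ccnc4[nH]ccc34)c2O1)N1CCNCC1` 930 nM
compound 3 `Cc1cc(Cl)cc(-c2ccnc3cc(CN4C(=O)C5C(C4=O)C5(C)C)sc23)c1OC1CCCNC1` 2.4 nM

In an assay on isolated protein for inhibition of ubiquitin carboxyl-terminal hydrolase 7 (Homo sapiens), read by fluorescence, with stated times of 30 min and 1 h (a higher number here means a weaker inhibitor, a lower number a stronger inhibitor), compound 1 gives the lowest of the three numbers. Compound 3 is the nearest to it, and the gap between them lies beyond the usual scatter, so compound 1 can be called the strongest inhibitor of the set. Compound 2 stands far weaker than both.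

Compound 4 `O=C1CCC(=O)N1Cc1cc2nccc(-c3cc(Cl)cc4c3O[C@@H](c3ocnc3CN3CCC3)C4)c2s1` has not yet been measured. It differs from compound 1 in one place: a group of 10 heavy atoms (7 carbon, 2 nitrogen, 1 oxygen; one four-membered non-aromatic ring with 1 hetero atom, one five-membered aromatic ring with 2 hetero atoms) in place of a group of 9 heavy atoms (6 carbon, 2 nitrogen, 1 oxygen; one five-membered aromatic ring with 2 hetero atoms, one six-membered non-aromatic ring with 1 hetero atom), on a saturated ring carbon. The hydrogen-bond donor of the leaving group is gone, while the count of acceptors stays the same, and the new group carries a four-membered ring on a methylene instead of a fused six-membered ring.

Among the compounds with values here, no step between two measured compounds shows what such a change does. Compound 3, which also carries a saturated ring with one nitrogen and one hydrogen-bond donor, sits not far from compound 1, so a change at this part of the molecule seems tolerated, though a moderate loss in this assay appears more likely than a gain.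

Compound 4 is therefore expected to show 2.5 nM in this assay, within a range of 0.5 nM to 12 nM. This estimate means a step from compound 1 to compound 4 of a 6.6-fold higher number from compound 1 to compound 4 (0.82 log units; beyond the scatter).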

Compound 4, half-maximal inhibitory concentration: 13 nM
For compound 4 the middle estimate is 5.2-fold (0.72 log units) below the measured one; the whole stated range lies below it.
By their numbers in this assay, from the lowest: compound 1; then compound 3; then compound 4; then compound 2.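

In this assay, within the data shown here, the one step available at this saturated ring carbon next to the ring oxygen is large: putting 4-((azetidin-1-yl)methyl)-1,3-oxazol-5-yl in place of the group with the six-membered non-aromatic ring gives a 34-fold higher number from compound 1 to compound 4 (1.53 log units; beyond the scatter). The position is therefore sensitive to the group it carries, although compound 4 still gives a nanomolar value of 13 nM. The change alters several features at once, as the entering group has 0 hydrogen-bond donors where the leaving group has 1, and its non-aromatic ring is four-membered and sits on a methylene rather than being fused, while no measurement here bears on the reason for the loss.

The compounds shown leave open which of these features accounts for the step, and a 1,3-oxazol-5-yl group with a primary amine on the same methylene would separate the hydrogen-bond donor from the ring change. They also leave open whether a pyrrolidine or piperidine on that methylene would behave differently from the azetidine.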